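The compounds below may be only part of what the source reports. "The series", "measured", "known", "first", "only" and "open" are said of these compounds alone.

Measured in a physicochemical assay for pharmacokinetics (a higher number here means that the compound lasts longer, a lower number that the compound disappears faster), all as limits:
- Compound 1 `O=C(NCc1ccccc1F)N1C(=O)c2ccccc2S1(=O)=O`: > 166 h
- Compound 2 `O=C(NCc1ccccc1Cl)N1C(=O)c2ccccc2S1(=O)=O`: > 166 h
- Compound 3 `O=C(c1ccccc1)N1C(=O)c2ccccc2S1(=O)=O`: > 0.875 h

As far as these compounds go, compound 3 stands at the limit of > 0.875 h in this assay, at which 1 of the 3 values shown sits, so its true position is unknown. The step to compound 4 `O=C(NCc1cccs1)N1C(=O)c2ccccc2S1(=O)=O` is ((thiophen-2-yl)methyl)amino in place of phenyl on a carbonyl carbon. In words, ((thiophen-2-yl)methyl)amino replaces phenyl on a carbonyl carbon.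

Within the data shown here, the only measured step is a step that the two limits leave unreadable from compound 1 to compound 2. It is a change of chloro in place of fluoro, so it offers no size to carry over. The closer guide is that compounds 1 and 2, like compound 4, have an amino group bearing an aromatic ring on that carbonyl carbon. Compound 1 has a limit of > 166 h. Compound 2 has the same kind of limit, > 166 h.

A step towards longer persistence in this assay is therefore expected, estimated as a step that the limit leaves unreadable from compound 3 to compound 4, although its starting point is only a limit. For compound 4 the expected half-life is 170 h, with an estimated range of 80 h to 350 h.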

Compound 4, half-life: > 166 h
Compound 4 gave a limit, no number; the forecaster's own chance of this, stated with the estimate: 75%; the middle value lies beyond the limit too.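

In this assay, among these compounds, compound 4 gives > 166 h, which is a limit, so no step from compound 1, compound 2 or compound 3 to compound 4 can be read. The compounds shown leave open what the actual half-life of each compound is, and whether ((thiophen-2-yl)methyl)amino in place of phenyl changes it.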